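An Indole in Place of an Indazole on a Shared Core

The compounds below may be only part of what the source reports. "The series", "measured", "known", "first", "only" and "open" are said of these compounds alone.

Measured so far:
compound 1, `Cn1c(=O)c(S(=O)(=O)c2ccc(F)cc2[N+](=O)[O-])cc2cnc(Nc3ccc4[nH]ccc4c3)nc21`: 900 nM
compound 2, `Cn1c(=O)c(S(=O)(=O)c2ccc(O)cc2)cc2cnc(Nc3ccc4[nH]ccc4c3)nc21`: 100 nM
compound 3, `Cn1c(=O)c(S(=O)(=O)c2ccc(F)cc2)cc2cnc(Nc3ccc4[nH]ncc4c3)nc21`: 10000 nM

Of the compounds shown here, three on the shared core have been measured in a functional assay on K562 cells (Homo sapiens) for inhibition, read by trypan blue exclusion, with a stated time of 72 h; on this read-out higher numbers stand for weaker inhibition and lower numbers for stronger inhibition. Compound 3 stands highest of the three numbers; compound 1 gives 900 nM and compound 2 gives 100 nM, both lower than compound 3 by more than the usual scatter.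

Going by the values given here, the one measured step, a 9.0-fold lower number from compound 1 to compound 2 (0.95 log units; beyond the scatter), alters the group on the sulfonyl sulfur and leaves the group on the nitrogen on the aromatic ring untouched. It therefore does not bear directly on the next compound. Compound 4, `Cn1c(=O)c(S(=O)(=O)c2ccc(F)cc2)cc2cnc(Nc3ccc4[nH]ccc4c3)nc21`, differs from compound 3 in one place: 1H-indol-5-yl in place of 1H-indazol-5-yl on a nitrogen on an aromatic ring. Compound 4 thereby carries the same 1H-indol-5-yl as compounds 1 and 2, while the group on its sulfonyl sulfur is neither that of compound 1 nor that of compound 2. Among the compounds with values here, no pair among the measured compounds isolates the indazole-to-indole change, so the expectation rests on where compounds 1 and 2 sit. The step of a 20-fold lower number from compound 3 to compound 4 (1.30 log units; beyond the scatter) is expected to be a fall beyond the scatter. Compound 4 is estimated at 500 nM, within a range from 100 nM to 3000 nM.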

Compound 4, half-maximal inhibitory concentration: 200 nM
Estimate against measurement, compound 4: 2.5-fold (0.40 log units) above, within the range that was stated.
By their numbers in this assay, from the lowest: compounds 2 and 4 (each within the scatter of the next); then compound 1; then compound 3.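

In this assay, the exchange of 1H-indazol-5-yl for 1H-indol-5-yl on a nitrogen on an aromatic ring is isolated by a single pair, which shows a 50-fold lower number from compound 3 to compound 4 (1.70 log units; beyond the scatter), the largest step among the compounds shown. With 1H-indol-5-yl held constant, compound 4 also makes the group on the sulfonyl sulfur readable: fluoro in place of hydroxy on an aromatic carbon gives a 2.0-fold higher number from compound 2 to compound 4 (0.30 log units; within the scatter), while hydrogen in place of nitro on an aromatic carbon gives a 4.5-fold lower number from compound 1 to compound 4 (0.65 log units; beyond the scatter), so both of these steps are smaller than the exchange at the nitrogen. Nothing available here explains why that exchange has so large an effect.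

The compounds shown leave open whether the gap between 1H-indazol-5-yl and 1H-indol-5-yl has the same size when the group on the sulfonyl sulfur carries hydroxy or nitro, since the pair rests on the fluoro compounds alone. They also leave open how an amine or a carboxylic acid on the ring attached to the sulfonyl sulfur, or a benzimidazole in place of the indole on the nitrogen, would read in this assay.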